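Replacing a dichlorophenyl group with a chlorophenyl thioether

The compounds below may be only part of what the source reports. "The series", "measured", "known", "first", "only" and "open" are said of these compounds alone.

For the measured compounds named here, compound 2, `Cc1cc(-c2cc(Cl)cc(Cl)c2)c(S(C)(=O)=O)cc1C(=O)N=C(N)N`, stands at the weak end of the two numbers known so far: in a functional assay for inhibition of sodium/hydrogen exchanger (Oryctolagus cuniculus) (on this read-out lower numbers stand for stronger inhibition and higher numbers for weaker inhibition), compound 2 gives 130 nM, the highest value among the measured pair. Going by the values given here, its only measured neighbour is compound 1, `Cc1cc(Br)c(S(C)(=O)=O)cc1C(=O)N=C(N)N`, which in this assay gives 12 nM. Among the compounds with values here, the step of an 11-fold higher number from compound 1 to compound 2 (1.03 log units; beyond the scatter) is the one change recorded here, and it went with the exchange of a bromo for a 3,5-dichlorophenyl group.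

Compound 3, `Cc1cc(Sc2cccc(Cl)c2)c(S(C)(=O)=O)cc1C(=O)N=C(N)N`, is reached from compound 2 by the change ((3-chlorophenyl)sulfanyl in place of 3,5-dichlorophenyl on an aromatic carbon). Within the data shown here, no measured step describes what happens when a thioether-linked aryl group takes the place of a directly bound aryl group, so the only guidance is that an eight-atom aryl substituent at this position already gave a high number in compound 2. The expected step of a 1.3-fold lower number from compound 2 to compound 3 (0.11 log units; within the scatter) is therefore small, with no clear direction beyond the scatter. Compound 3 is expected to give about 100 nM in this assay, with a plausible range from 25 nM to 400 nM.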

Compound 3, half-maximal inhibitory concentration: 37 nM
Estimate against measurement, compound 3: 2.7-fold (0.43 log units) above, within the range that was stated.
By their numbers in this assay, from the lowest: compound 1; then compound 3; then compound 2.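

In this assay, the new result shows that the number at this position is not set by the count of heavy atoms in the group alone: 3,5-dichlorophenyl and (3-chlorophenyl)sulfanyl both have 8 heavy atoms, yet the exchange goes with a 3.5-fold lower number from compound 2 to compound 3 (0.55 log units; beyond the scatter) and so recovers part of what was lost on leaving bromo. That recovery is only partial, since the thioether still shows a 3.1-fold higher number from compound 1 to compound 3 (0.49 log units; beyond the scatter) and bromo keeps the lowest number of the three compounds. No measurement among the data shown accounts for the difference between the two aryl-bearing compounds.

Two things change at once in the step to compound 3, with a sulfur entering and a chlorine leaving, so these compounds cannot separate the link through sulfur from the loss of the second chlorine. Also open is how the number would respond to a group of another kind on this carbon, such as an amine, a carboxylic acid or a longer alkyl chain, since only bromo and the two chlorinated aryl groups are shown here.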